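The source may report more compounds than this note shows. Statements on the series, on what has been measured and on what is new or still open speak of the compounds shown alone.

Measured so far in an assay on membranes from CHO cells for displacement of a labelled ligand from adenosine receptor A1 (Homo sapiens), read by scintillation counting, with a stated time of 60 min, tested at 1 uM; on this read-out higher numbers stand for more inhibition at the one concentration tested (going by the name of the read-out) and lower numbers for less inhibition:
compound 1 `CC1=C(C(=O)CC(C)C)C(c2ccoc2)NC(=O)N1` — 23%
compound 2 `CCNC(=O)C1=C(C)NC(=O)NC1c1ccco1` — 2%
compound 3 `CC1=C(C(N)=O)C(c2ccoc2)NC(=O)N1` — 1%

Compound 3 stands lowest of the three numbers; compound 2 sits within the scatter of it, while compound 1 lies well above it. Within the data shown here, the one step on record, a number 22 percentage points lower from compound 1 to compound 3 (beyond the scatter), concerns a change on the carbonyl carbon and does not bear directly on an alkyl group entering at the amide nitrogen.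

Compound 4 `CCNC(=O)C1=C(C)NC(=O)NC1c1ccoc1` differs from compound 3 by ethyl in place of hydrogen on an amide-type nitrogen. Compound 2 carries an ethylcarbamoyl group as well and gives a number within the scatter of compound 3, though it differs in more than one place. Given that, no shift beyond the scatter is expected for compound 4: a number 3 percentage points higher from compound 3 to compound 4 (within the scatter). The estimate for compound 4 is 4%, range 0% to 15%.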

Compound 4, a percentage reported as inhibition, at one concentration (the size of the read-out at that concentration, not a potency): 1%
Estimate against measurement, compound 4: 3 percentage points above, and the stated range covers the measured number.
By their numbers in this assay, from the lowest: compounds 3, 4 and 2 (each within the scatter of the next); then compound 1.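

In this assay, ethyl in place of hydrogen on the amide-type nitrogen gives no change at the digits printed from compound 3 to compound 4 (within the scatter), and furan-3-yl in place of furan-2-yl gives a number 1 percentage points lower from compound 2 to compound 4 (within the scatter), so neither change separates these compounds. Ethylamino in place of isobutyl on the carbonyl carbon gives a number 22 percentage points lower from compound 1 to compound 4 (beyond the scatter), a step of similar size to the amino case, a number 22 percentage points lower from compound 1 to compound 3 (beyond the scatter). No supporting data explain these numbers.

Open, going by these compounds, is whether a longer chain on the amide-type nitrogen would move the number. On these data alone, a carboxylic acid or a propyl ketone on the carbonyl carbon is equally open.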